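Swapping a trimethylpyrazole for a pyridine in lipophilicity

The source may hold more compounds than are shown below. What is called first, only, known or untested is meant among the compounds shown, and "the series" means these compounds.

Of the compounds shown here, three sharing one core have been measured in a physicochemical assay for lipophilicity; on this read-out lower numbers stand for lower lipophilicity and higher numbers for higher lipophilicity. Compound 1, `Cc1cc(C)c(-c2ncc[nH]2)cc1NC(=O)c1ccc(OCc2ccccn2)cc1`, gives 3.1. Compound 2, `Cc1cc(C)c(-c2nc3ccccc3[nH]2)cc1NC(=O)c1ccc(OCc2ccccn2)cc1`, gives > 3.5, which is a limit of the assay and not a number. Compound 3, `Cc1cc(C)c(-c2c(C)nn(C)c2C)cc1NC(=O)c1ccc(OCc2ccccn2)cc1`, likewise gives only a limit, > 3. Among the compounds with values here, the one readable step, a number at least 0.40 log units higher from compound 1 to compound 2 (beyond the scatter), changes the group attached to the core. Because compound 3 sits at the limit of > 3 in this assay, at which 1 of the 3 values shown sits, the step that the limit leaves unreadable from compound 1 to compound 3 cannot be sized. The step that the two limits leave unreadable from compound 2 to compound 3 is equally unreadable because compound 2 sits at the limit of > 3.5 in this assay, at which 1 of the 3 values shown sits.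

Compound 4, `Cc1cc(C)c(-c2ccccn2)cc1NC(=O)c1ccc(OCc2ccccn2)cc1`, has not yet been measured. It differs from compound 3 in one place: pyridin-2-yl in place of 1,3,5-trimethyl-1H-pyrazol-4-yl on an aromatic carbon. Within the data shown here, no measured step replaces this group with a pyridin-2-yl, so the two unreadable steps touching compound 3 are the only ones that bear on the change, and they fix no size. With compound 3 known only to lie at its limit, a move in either direction beyond the scatter would itself be hard to read. Compound 4 is expected to give about 3.6, within a range from 3.1 to 4.1. The step that this estimate implies is a step that the limit leaves unreadable from compound 3 to compound 4.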

Compound 4, distribution coefficient: > 3
Compound 4 ended at the assay's limit (the forecaster's own chance of this, stated with the estimate: 45%); the middle value lies beyond the limit too.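

In this assay compound 4 gives > 3, which is a limit of the assay and not a number. The steps linking compound 4 with compound 1, compound 2 and compound 3 cannot be read because compound 4 sits at a limit: the limit of > 3 in this assay, at which 2 of the 4 values shown sit.

Going by these compounds, how far pyridin-2-yl and 1,3,5-trimethyl-1H-pyrazol-4-yl separate compound 4 from compound 3 in this assay remains open.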